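A few compounds are considered here, and "the series" means these few. Any claim that something is new, unique, unknown or untested is made for them only; others in the source may bear on it.

Compound 1 `CCC(C)NS(=O)(=O)c1ccc(F)c(C(=O)NCc2ccc(F)c(F)c2)c1`: > 50000 nM (a limit)
Compound 2 `O=C(NCc1ccccc1)c1ccc(Cl)c(S(=O)(=O)N2CCCCCC2)c1`: > 50000 nM (a limit)

The two compounds were tested in an ADME assay on HepDES19 cells (Homo sapiens) for cytotoxicity, read by MTT assay, with a stated time of 48 h; a lower number here means that less compound is tolerated, a higher number that more compound is tolerated. Compound 1 gives > 50000 nM, which is a limit of the assay and not a number. Compound 2 gives > 50000 nM, which is also a limit. The record for this assay therefore holds no numerical value, only (the limit of > 50000 nM in this assay, at which 2 of the 2 values shown sit), and compound 1 stands at that limit.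

Compound 3 `O=C(NCc1ccc(F)c(F)c1)c1cc(S(=O)(=O)NC2CCCC2)ccc1F` keeps the core of compound 1 and differs from it in one place, with cyclopentyl in place of sec-butyl on a sulfonamide nitrogen. Within the data shown here, no measured step between two compounds is available to show what such a change does in this assay. The expectation therefore rests on compound 1 alone, whose limit is > 50000 nM. No step beyond the usual scatter is expected, and no direction is favoured. The estimated step of a number no higher from compound 1 to compound 3 (the limit leaves the size open) is accordingly expected to be small. Compound 3 is expected at 50000 nM, with an estimated range from 25000 nM to 80000 nM, and the assay may well report only a limit.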

Compound 3, half-maximal cytotoxic concentration: > 50000 nM
Compound 3: no number, only a limit; the forecaster's own chance of this, stated with the estimate: 85%; the middle value sits exactly at the limit.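

In this assay compound 3 gives > 50000 nM, which is a limit and not a number. No step can therefore be read between compound 1 and compound 3, and the record holds only limits: the limit of > 50000 nM in this assay, at which 3 of the 3 values shown sit.

The compounds shown leave open what numerical value any of them would reach, and whether cyclopentyl in place of sec-butyl on a sulfonamide nitrogen changes the read-out at all.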